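From dimethylamino to (propanoyloxy)methyl, starting at the limit

The compounds below may be only part of what the source reports. "The series", "measured", "known", "first", "only" and "open" are said of these compounds alone.

In a functional assay on HeLa cells (Homo sapiens) for cytotoxicity, read by neutral red uptake, with a stated time of 3 days (a higher number here means a weaker inhibitor, a lower number a stronger inhibitor), compound 1 `Nc1ccc(-c2cc(=O)c3c(N)c(F)c(O)c(F)c3o2)cc1F` gives > 100000 nM, which is a limit of the assay and not a number. Compound 2 `CN(C)c1c(F)c(N)c2c(=O)cc(-c3ccc(N)c(F)c3)oc2c1F` gives > 100000 nM in this assay, which is again a limit. Compound 2 therefore has no readable position in the series, and the whole picture so far is the limit of > 100000 nM in this assay, at which 2 of the 2 values shown sit.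

Among the measured compounds shown here, the only measured step is a step that the two limits leave unreadable from compound 1 to compound 2, with dimethylamino in place of hydroxy on an aromatic carbon. It gives no size or direction to carry forward.

Compound 3 `CCC(=O)OCc1c(F)c(N)c2c(=O)cc(-c3ccc(N)c(F)c3)oc2c1F` has not yet been measured. It carries (propanoyloxy)methyl in place of dimethylamino on an aromatic carbon, ortho to two fluoro groups: (propanoyloxy)methyl in place of dimethylamino on an aromatic carbon.

The expectation rests on compound 2, whose > 100000 nM is a limit, and no shift beyond the scatter is expected in this assay. The expected step is a number no higher from compound 2 to compound 3 (the limit leaves the size open). For the measured compounds named here, this is a weak expectation, as no measured step has a readable size. For compound 3 the estimate is 100000 nM, with an expected range of 30000 nM to 300000 nM.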

Compound 3, half-maximal inhibitory concentration: 69000 nM
Estimate against measurement, compound 3: 1.4-fold (0.16 log units) above, and the stated range covers the measured number.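

In this assay, among the compounds shown here, compound 3 gives 69000 nM, the first value at this position, ortho to two fluoro groups, that is a number and not a limit. The change of group reads as an at least 1.4-fold lower number from compound 2 to compound 3 (0.16 log units; that floor lies within the scatter), and the change from hydroxy reads as an at least 1.4-fold lower number from compound 1 to compound 3 (0.16 log units; that floor lies within the scatter); each is only a floor, so the true size of either step stays unknown and neither is shown to lie beyond the scatter. This position can therefore carry a group of the size of (propanoyloxy)methyl and return a readable number, but the series as a whole still rests mainly on one limit: the limit of > 100000 nM in this assay, at which 2 of the 3 values shown sit.

Left open is whether the ester itself or simply a carbon attached to the ring goes with the readable number, a question that a hydroxymethyl or a plain methyl group at this position would address. Also open, going by these compounds, is whether a longer acyl chain, such as butanoyloxymethyl, or a carboxylic acid at the same position would move the number in this assay clearly beyond the scatter.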